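The source may hold more compounds than are shown below. What is called first, only, known or untested is meant among the compounds shown, and "the series" means these compounds.

Of the compounds shown here, two carry numbers so far, compound 1 as `Cc1cc(C)nc(Sc2ccnc(Nc3ccc(C#N)cc3)n2)n1` and compound 2 as `N#Cc1ccc(Nc2nccc(OCc3ccccc3F)n2)cc1`. In an ADME assay on MT4 cells (Homo sapiens) for cytotoxicity, read by MTT assay, with a stated time of 5 days (a lower number here means that less compound is tolerated, a higher number that more compound is tolerated), compound 1 gives 224000 nM; compound 2 gives 151000 nM, the lowest of the two numbers, though its gap to compound 1 stays within the usual scatter. Compound 3, `N#Cc1ccc(Nc2nccc(OCc3cccc(C#N)c3)n2)cc1`, awaits measurement. The change from compound 2 is 3-cyanophenyl in place of 2-fluorophenyl on a saturated chain carbon bound to an oxygen on an aromatic ring. Among the compounds with values here, no measured pair isolates this change. No shift beyond the scatter is expected, so the estimated step is a 1.1-fold higher number from compound 2 to compound 3 (0.05 log units; within the scatter). Compound 3 is accordingly expected to give about 170000 nM in this assay, within a range from 70000 nM to 350000 nM.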

Compound 3, half-maximal cytotoxic concentration: 4100 nM
The estimate for compound 3 lay 41-fold (1.62 log units) above the measured number, and the stated range ends above it.
By their numbers in this assay, from the lowest: compound 3; then compounds 2 and 1 (each within the scatter of the next).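

In this assay, the group on a saturated chain carbon bound to an oxygen on an aromatic ring proves able to move the number far beyond the scatter: 3-cyanophenyl in place of 2-fluorophenyl gives a 37-fold lower number from compound 2 to compound 3 (1.57 log units; beyond the scatter). Less compound is therefore tolerated with the nitrile-bearing ring, and this is the first single-place change read in the series. No measurement at hand offers a reason for this step. This one step does not separate the gain of the nitrile from the loss of the fluorine. As far as these compounds go, how an amine or a carboxylic acid on that ring would read remains open.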